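A few compounds are considered here, and "the series" means these few. Any claim that something is new, unique, unknown or untested is made for them only; others in the source may bear on it.

Measured so far in a functional assay on SW480 cells (Homo sapiens) for inhibition; on this read-out lower numbers stand for stronger inhibition and higher numbers for weaker inhibition:
- compound 1 `CN[C@H](C#Cc1c(F)ccc2c1/C(=C/c1[nH]ccc1OC)C(=O)N2)CO`: 100 nM
- compound 2 `COc1cc[nH]c1/C=C1\C(=O)Nc2ccc(F)c(C#C[C@@H](N)[C@@H](C)O)c21`: 210 nM
- compound 3 `COc1cc[nH]c1/C=C1\C(=O)Nc2ccc(F)c(C#C[C@@H](NS(C)(=O)=O)[C@@H](C)O)c21`: 1190 nM

Compound 3 gives the highest number of the three; its nearest neighbour is compound 2, from which the step is a 5.7-fold higher number from compound 2 to compound 3 (0.75 log units; beyond the scatter), and the step from compound 1 is a 12-fold higher number from compound 1 to compound 3 (1.08 log units; beyond the scatter). Compound 4 `COc1cc[nH]c1/C=C1\C(=O)Nc2ccc(F)c(C#C[C@@H]3CCCN3)c21` is the next member; it differs from compound 3 in this way: pyrrolidin-2-yl in place of 2-hydroxy-1-(methanesulfonamido)propyl on a triple-bonded carbon.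

Within the data shown here, two measured steps bear on the change. The step of a 5.7-fold higher number from compound 2 to compound 3 (0.75 log units; beyond the scatter) came from methylsulfonyl in place of hydrogen on an amine nitrogen; compound 4 no longer carries the methanesulfonamido group, so that step is read in reverse. The step of a 2.1-fold higher number from compound 1 to compound 2 (0.32 log units; beyond the scatter) shows that the difference between the amine variants of compound 1 and compound 2 is modest, and compound 4 keeps an amine with one hydrogen-bond donor. Among the measured compounds shown here, the hydroxyl of compound 3 also leaves, and no measured pair shows what that alone does.

Compound 4 is therefore expected to come in with a number in the region of compound 1 and compound 2, a step of a 6.0-fold lower number from compound 3 to compound 4 (0.77 log units; beyond the scatter); the estimate for compound 4 is 200 nM, with a range from 70 nM to 600 nM.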

Compound 4, half-maximal inhibitory concentration: 40 nM
Compound 4: the middle estimate sits 5.0-fold (0.70 log units) above what was measured; the measured number lies below the stated range.
By their numbers in this assay, from the lowest: compound 4; then compound 1; then compound 2; then compound 3.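

In this assay the triple-bonded carbon accepts a pyrrolidin-2-yl ring with no hydroxyl in the group, and this ring improves on both open-chain amines: a 5.3-fold lower number from compound 2 to compound 4 (0.72 log units; beyond the scatter) and a 2.5-fold lower number from compound 1 to compound 4 (0.40 log units; beyond the scatter). Among these compounds, the hydroxyl carried by compound 1, compound 2 and compound 3 is therefore not required for the lowest number, and replacing the whole 2-hydroxy-1-(methanesulfonamido)propyl group gives the largest step so far, a 30-fold lower number from compound 3 to compound 4 (1.47 log units; beyond the scatter). Nothing available explains these steps.

The shown compounds do not separate the contribution of the ring from that of losing the hydroxyl; an open-chain methylamino group without a hydroxyl, or a pyrrolidin-2-yl bearing a hydroxyl, would part the two. Also open, going by these compounds, are the six-membered piperidin-2-yl ring, a methyl on the ring nitrogen and the opposite stereocentre of the pyrrolidin-2-yl group.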